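The source may hold more compounds than are shown below. What is called first, only, known or untested is meant among the compounds shown, and "the series" means these compounds.

Working notes on the series. Compound 1 `Cc1c(C=O)oc2c(C(N)=O)c(O)cc(O)c12` carries a formyl group and a primary amide on the shared core, and in a functional assay on NSCLC-N6 cells (Homo sapiens) for cytotoxicity, read by MTT assay (a higher number here means a weaker inhibitor, a lower number a stronger inhibitor), compound 1 gives 60800 nM. Compound 2 `CCOC(=O)c1oc2cc(OCc3ccccc3)cc(OCc3ccccc3)c2c1C` has two benzyloxy groups and an ethyl ester in place of the formyl group. In this assay compound 2 gives only a limit, > 72000 nM, and no number. That reading sits at the limit of > 72000 nM in this assay, at which 1 of the 2 values shown sits, so where compound 2 truly stands is not known beyond that bound.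

Going by the values given here, no pair of measured compounds differs in one place, so no measured step is at hand to lean on. Compound 3 `Cc1c(C=O)oc2cc(OCc3ccccc3)cc(OCc3ccccc3)c12` is the next member: it differs from compound 2 by hydrogen in place of ethoxy on a carbonyl carbon. Compound 1 also carries a formyl group and is measured, but differs from compound 3 in more than one place, so its value only says that a formyl-bearing member of the series can give a number rather than a limit.

For compound 3 the expected step of an at least 1.2-fold lower number from compound 2 to compound 3 (0.07 log units; that floor lies within the scatter) is small, perhaps toward a slightly stronger inhibitor, though a limit is nearly as likely as a number. Compound 3 is estimated at 60000 nM, with a range from 15000 nM to 200000 nM.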

Compound 3, half-maximal inhibitory concentration: > 80600 nM
Compound 3 was reported as a limit (the forecaster's own chance of this, stated with the estimate: 45%); middle value at least 1.3-fold (0.12 log units) from the limit.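

In this assay compound 2 stands only as a limit, > 72000 nM. Compound 3 likewise stands only as a limit, > 80600 nM. Going by these compounds alone, with two limits, no step between compound 2 and compound 3 can be read. The compounds shown leave open whether hydrogen in place of ethoxy on a carbonyl carbon changes the reading at all.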